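From an Acetyl to a Chlorophenylsulfonyl Group

This account rests on a few compounds, and the source may have more. Where it says the series, first, only, none or still open, it means among the compounds named here.

Compound 1 `COc1ccc(-c2c(C)nc3c(N4CC[C@@H](NC(C)=O)C4)cc(C)nn23)cc1OC` was tested in an ADME assay on microsomes from liver (Homo sapiens) for metabolic stability, read by LC-MS, with NADPH named in the record, with a stated time of 60 min, tested at 1 uM, in the absence of a further agent; on this read-out higher numbers stand for a more stable compound and lower numbers for a less stable compound. Compound 1 reaches > 95%, which is a limit of the assay rather than a number. Compound 2 `CC(=O)N[C@@H]1CCN(c2cc(C)nn3c(-c4ccco4)c(C)nc23)C1` differs from compound 1 only in carrying furan-2-yl in place of 3,4-dimethoxyphenyl on an aromatic carbon. In this assay compound 2 also reaches > 95%, again a limit of the assay and not a number. The step that the two limits leave unreadable from compound 1 to compound 2 therefore cannot be read, because of the limit of > 95% in this assay, at which 2 of the 2 values shown sit.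

Compound 3 `COc1ccc(-c2c(C)nc3c(N4CC[C@@H](NS(=O)(=O)c5ccc(Cl)cc5)C4)cc(C)nn23)cc1OC` is not yet measured. It differs from compound 1 at another place: (4-chlorophenyl)sulfonyl in place of acetyl on an amine nitrogen. For the measured compounds named here, no measured step touches the amine nitrogen, and the one step that was measured, at an aromatic carbon, yields no readable size. The expectation for compound 3 therefore rests on compound 1 alone, whose limit leaves the true starting point open. Compound 3 is estimated at 78%, between 45% and 97%. The step of a number at least 17 percentage points lower from compound 1 to compound 3 (beyond the scatter) expected in this assay leans toward a less stable compound, but the limit of compound 1 makes its size uncertain.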

Compound 3, percent of the compound remaining: > 95%
Compound 3 ended at the assay's limit; the forecaster's own chance of this, stated with the estimate: 30%; middle value at least 17 percentage points from the limit.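

In this assay, the step between compound 1 and compound 3 cannot be read, because both values are limits of the assay rather than numbers: the limit of > 95% in this assay, at which 3 of the 3 values shown sit.

The compounds shown leave open whether (4-chlorophenyl)sulfonyl in place of acetyl changes the stability at all, and how compound 1, compound 2 and compound 3 truly rank.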